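The source may hold more compounds than are shown below. What is called first, only, known or untested is meant among the compounds shown, and "the series" means these compounds.

Of the compounds shown here, two of one shared core have been tested in an ADME assay on cells (Mus musculus, strain Balb/c) for cytotoxicity, read by MTT assay, with a stated time of 48 h; on this read-out higher numbers stand for lower toxicity in this test and lower numbers for higher toxicity in this test. Compound 1, with structure `COc1ccc(C(/C=C/c2ccc(Cl)cc2)=N/O)cc1`, gives 291000 nM. Compound 2, with structure `COc1ccc(C(/C=C/c2ccc(Br)cc2)=N/O)cc1`, gives 737000 nM. Among the compounds with values here, the only change between them, bromo in place of chloro on an aromatic carbon, brings a 2.5-fold higher number from compound 1 to compound 2 (0.40 log units; beyond the scatter). On the numbers seen so far, compound 1 stands as the lower of the two measured values, the higher one belonging to compound 2.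

Compound 3, with structure `COc1ccc(C(/C=C/c2ccc(Cl)cc2Cl)=N/O)cc1`, is not yet measured. It differs from compound 1 in one place: chloro in place of hydrogen on an aromatic carbon. Within the data shown here, no measured step shows what a second chloro group on this ring does; the single step at hand swaps one halogen for another and was modest in size. Because that step gave a 2.5-fold higher number from compound 1 to compound 2 (0.40 log units; beyond the scatter), a change to the same ring that keeps the first chloro and adds a second is expected to shift this assay only a little, if at all, with no firm direction. Compound 3 is therefore expected to give about 300000 nM, within a range of 120000 nM to 800000 nM, which means an expected step of a 1.0-fold higher number from compound 1 to compound 3 (0.01 log units; within the scatter).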

Compound 3, half-maximal cytotoxic concentration: 25000 nM
Compound 3: the middle estimate sits 12-fold (1.08 log units) above what was measured; measured number outside the range, below it.
By their numbers in this assay, from the lowest: compound 3; then compound 1; then compound 2.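

In this assay adding a chloro group on an aromatic carbon, ortho to a large group and meta to the chloro group already present, gives a 12-fold lower number from compound 1 to compound 3 (1.07 log units; beyond the scatter) and shows that this place on the ring is far from silent. A single added heavy atom here moves the number much further than the swap of one halogen for another, which gave a 2.5-fold higher number from compound 1 to compound 2 (0.40 log units; beyond the scatter) and ran the opposite way, toward lower toxicity in this test rather than higher. No measurement shown here accounts for the size or the direction of the new step.

The compounds shown leave open whether a fluoro, a methyl or an amino group at this same place would bring a similar fall in the number, or whether the effect is particular to chloro. Going by these compounds, it also remains open whether the same added chloro would act in the same way on compound 2, where bromo takes the place of the first chloro.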